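The compounds below may be only part of what the source reports. "The series", "measured", "known", "first", "only" and "open" are said of these compounds alone.

Measured so far:
Compound 1, `CCOC(=O)C1=Cc2ccccc2OC1(OCc1cn(-c2ccc(F)cc2)nn1)C(F)(F)F`, in a functional assay on HeLa cells (Homo sapiens) for inhibition, read by MTT assay, with a stated time of 24 h (a higher number here means a weaker inhibitor, a lower number a stronger inhibitor), gives 8400 nM.
Compound 2, `CCOC(=O)C1=Cc2ccccc2OC1(OCc1cc(-c2ccc(Br)cc2)no1)C(F)(F)F`, in this assay gives 52300 nM.

Compound 1 has the lower of the two numbers, and compound 2 stands at a higher number, a gap beyond the usual scatter of repeated measurements; compound 1 is thus the stronger inhibitor of the pair. Within the data shown here, no step between two measured compounds that differ in a single place has been measured, so nothing shows how one change alone moves the number.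

Compound 3, `CCOC(=O)C1=Cc2ccccc2OC1(OCc1cn(-c2ccc([N+](=O)[O-])cc2)nn1)C(F)(F)F`, is the next compound to be tested in this assay. It differs from compound 1 in one place: nitro in place of fluoro on an aromatic carbon. The shared core is unchanged. Among the measured compounds shown here, with no measured step to lean on, the step of a 1.3-fold lower number from compound 1 to compound 3 (0.11 log units; within the scatter) is expected to be small, in either direction or none beyond the scatter. Compound 3 is estimated at 6500 nM, with a range from 2000 nM to 20000 nM.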

Compound 3, half-maximal inhibitory concentration: > 150000 nM
Compound 3 gave a limit, no number; the forecaster's own chance of this, stated with the estimate: 5%; middle value at least 23-fold (1.36 log units) from the limit.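

In this assay, compound 3 gives only a limit of the assay, not a number: the limit of > 150000 nM in this assay, at which 1 of the 3 values shown sits.

Even so, the change from 4-fluorophenyl to 4-nitrophenyl can be read as a minimum, an at least 17-fold higher number from compound 1 to compound 3 (1.25 log units; beyond the scatter), which makes compound 3 the far weaker inhibitor. Among these compounds, compound 1 and compound 2 differ in more than one place, so this is the only step here that isolates a single change, and it shows that the group on this aromatic carbon, para to a large group, can strongly move the number in this assay.

As far as these compounds go, how large the step truly is remains open, as does which feature of nitro matters. Nor do these compounds show whether a hydrogen, a chloro, a methoxy or an amine in the same place would keep the inhibition of compound 1.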